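Swapping the Ring Nitrogen Out of the Amide Side Chain

The compounds below may be only part of what the source reports. "The series", "measured", "known", "first", "only" and "open" are said of these compounds alone.

Compound 2 `CCOc1ncc(-c2nc(C(F)(F)F)sc2N2CCN(C(=O)Cn3cnc4cccnc43)[C@H](C)C2)cn1` gives 20 nM in a functional assay on U2OS cells for antagonist activity at C-X-C chemokine receptor type 3 (Homo sapiens), read by beta-arrestin recruitment (on this read-out lower numbers stand for stronger inhibition and higher numbers for weaker inhibition), the lowest of the two numbers shown; compound 1 `COc1ccc(-c2nc(C(F)(F)F)sc2N2CCN(C(=O)Cn3cnc4cccnc43)[C@H](C)C2)cc1` gives 131 nM, and the step of a 6.6-fold lower number from compound 1 to compound 2 (0.82 log units; beyond the scatter). Compound 3 `CCOc1ncc(-c2nc(C(F)(F)F)sc2N2CCN(C(=O)Cn3cnc4ccccc43)[C@H](C)C2)cn1` differs from compound 2 by a group of 9 heavy atoms (7 carbon, 2 nitrogen; one five-membered aromatic ring with 2 hetero atoms, one six-membered aromatic ring of carbon only) in place of a group of 9 heavy atoms (6 carbon, 3 nitrogen; one five-membered aromatic ring with 2 hetero atoms, one six-membered aromatic ring with 1 hetero atom), on a saturated chain carbon bound to a carbonyl carbon. Within the data shown here, no measured step touches this part of the molecule, and the only step known lies elsewhere, so there is nothing to predict a direction from; the expectation is a step of about a 1.5-fold higher number from compound 2 to compound 3 (0.18 log units; within the scatter), within the scatter. Compound 3 is therefore estimated at 30 nM, in a range from 10 nM to 100 nM.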

Compound 3, half-maximal inhibitory concentration: 49 nM
The estimate for compound 3 lay 1.6-fold (0.21 log units) below the measured number; the range from low to high includes it.
By their numbers in this assay, from the lowest: compound 2; then compound 3; then compound 1.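

In this assay, among these compounds, the first step at this position shows that the side chain is not indifferent to this change: 1H-benzimidazol-1-yl, whose six-membered aromatic ring is of carbon only, replaces a group whose six-membered aromatic ring holds a hetero atom, giving a 2.5-fold higher number from compound 2 to compound 3 (0.39 log units; beyond the scatter). No measurement at hand explains why the number rises with this swap.

From the compounds shown here alone, whether an amine or a methoxy group on that six-membered ring would lower or raise the number stays open. So does whether the same swap would act alike with the 4-methoxyphenyl group of compound 1.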